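The source may hold more compounds than are shown below. What is called first, only, known or untested is meant among the compounds shown, and "the series" means these compounds.

Of the compounds shown here, three share one core and have been tested in an ADME assay on Huh7.5.1 cells (Homo sapiens) for cytotoxicity, read by ATP content, with a stated time of 48 h; on this read-out higher numbers stand for lower toxicity in this test and lower numbers for higher toxicity in this test. Compound 1 `Cc1ccccc1-c1nc(CN2CCC(C(=O)NCCCN3CCC(C(C)C)CC3)CC2)c(C)o1` gives 4280 nM. Compound 3 `Cc1cccc(Cl)c1-c1nc(CN2CCC(C(=O)NCCCN3CCC(C(C)C)CC3)CC2)c(C)o1` gives 4910 nM. Compound 2 `Cc1oc(-c2ccc(Cl)c(Cl)c2)nc1CN1CCC(C(=O)NCCCN2C[C@H](C)C[C@H](C)C2)CC1` gives 3170 nM; this sits at the low end of the three numbers, but its gaps to compound 1 and to compound 3 both lie within the scatter, so no real ordering can be read from them.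

Compound 4 `COc1cccc(C)c1-c1nc(CN2CCC(C(=O)NCCCN3C[C@H](C)C[C@H](C)C3)CC2)c(C)o1` is the next compound. Compared with compound 2, the change is 2-methoxy-6-methylphenyl in place of 3,4-dichlorophenyl on an aromatic carbon, on the five-membered aromatic ring of the shared core.

Within the data shown here, only one measured step concerns a change on the aromatic group at that place: a 1.1-fold higher number from compound 1 to compound 3 (0.06 log units; within the scatter). Among the measured compounds shown here, no measured step swaps the whole aromatic group for another. With so little to go on, the expectation is that compound 4 will stay close to compound 2 in this assay, with a step of a 1.1-fold higher number from compound 2 to compound 4 (0.06 log units; within the scatter) that is expected to be within the scatter. Compound 4 is therefore estimated at 3600 nM, with a likely range from 1700 nM to 7500 nM.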

Compound 4, half-maximal cytotoxic concentration: 16700 nM
For compound 4 the middle estimate is 4.6-fold (0.67 log units) below the measured one; the whole stated range lies below it.
By their numbers in this assay, from the lowest: compounds 2, 1 and 3 (each within the scatter of the next); then compound 4.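

In this assay, the aromatic group on the five-membered ring of the shared core can clearly move the number: 2-methoxy-6-methylphenyl in place of 3,4-dichlorophenyl gives a 5.3-fold higher number from compound 2 to compound 4 (0.72 log units; beyond the scatter), which points to lower toxicity in this test. Among these compounds, the only earlier step at this group, a 1.1-fold higher number from compound 1 to compound 3 (0.06 log units; within the scatter), stayed within the scatter, so the compounds before this one gave no sign that a change here could matter. Among the compounds shown here, this step is modest, but it is the first at this place to rise above the usual noise. Nothing available here bears on what lies behind the step.

The whole group changes at once, so the compounds shown leave open whether the methoxy, the methyl or the loss of both chlorines carries the step. As far as these compounds go, how a phenyl bearing only a methoxy, or one bearing an amine, would behave also stays open.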